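The source may hold more compounds than are shown below. What is called first, only, known or untested is meant among the compounds shown, and "the series" means these compounds.

Two agonists of the oxoeicosanoid receptor have been characterised in a functional assay on cells for agonist activity at Oxoeicosanoid receptor 1 (Homo sapiens), read by beta-arrestin recruitment; on this read-out higher numbers stand for larger maximal responses and lower numbers for smaller maximal responses. Compound 1 `CCCCC/C=C\C/C=C\C/C=C\C=C\C(=O)CCCC(=O)OC` gives 133% in this assay, while compound 2 `CC/C=C\C/C=C\C/C=C\C/C=C\C=C\C(=O)CCCC(=O)O` gives 80%. Compound 2 therefore stands lowest of the two values, with compound 1 a number higher by more than the scatter; the two structures differ in more than one place, so the values are simply reported side by side.

Compound 3 `CC/C=C\C/C=C\C/C=C\C/C=C\C=C\C(=O)CCCC(=O)OC` has not yet been measured in this assay. It differs from compound 2 by a single change, (methyl in place of hydrogen on an oxygen next to a carbonyl group). Within the data shown here, no step between compounds that differ in one place has been measured, so the effect of this change is open. The author expects an upward step of a number 30 percentage points higher from compound 2 to compound 3 (beyond the scatter) in this assay, because compound 1, which also carries methyl on an oxygen next to a carbonyl group, gives 133%. Compound 3 is estimated at 110%, within a range from 75% to 145%.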

Compound 3, largest response reached (Emax), in percent of the reference or control that the assay uses: 119%
Beside the measured number, compound 3's estimate is 9 percentage points below it; the range from low to high includes it.
By their numbers in this assay, from the lowest: compound 2; then compound 3; then compound 1.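

In this assay, among these compounds, the first one-place comparison at this position shows that methyl in place of hydrogen on an oxygen next to a carbonyl group, read as carboxy to methoxycarbonyl, gives a number 39 percentage points higher from compound 2 to compound 3 (beyond the scatter) on the shared core. The chain can now be read on its own as well: with methoxycarbonyl held constant, but-1-en-1-yl in place of butyl on a saturated chain carbon bound to a double-bonded chain carbon gives a number 14 percentage points lower from compound 1 to compound 3 (beyond the scatter), a step printed as modest where the methyl step is printed as large. Nothing available accounts for either step.

The compounds shown leave open how an ethoxycarbonyl group or a primary amide would read in place of methoxycarbonyl. They also leave open whether the methyl step holds on the butyl chain, where the carboxy counterpart of compound 1 would be needed.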